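A few compounds are considered here, and "the series" means these few. Any claim that something is new, unique, unknown or untested is made for them only; others in the source may bear on it.

Measured compounds:
compound 1, `CCC(C)[C@H](N)c1cc(C(F)(F)F)ccc1N1CCN(C(=O)CCc2ccc(OC)cc2Cl)CC1`, 57 nM in an assay on HEK293 cells for displacement of a labelled ligand from Melanocortin receptor 4 (Homo sapiens); a higher number here means a weaker inhibitor, a lower number a stronger inhibitor
compound 2, `CCC(C)[C@H](N)c1cc(C(F)(F)F)ccc1N1CCN(C(=O)CCc2ccc(OC)c(OC)c2Cl)CC1`, 2500 nM in this assay
compound 3, `CC(C)C[C@H](N)c1cc(C(F)(F)F)ccc1N1CCN(C(=O)CCc2ccccc2Cl)CC1`, 1700 nM in this assay

Compound 3 stands second highest of the three numbers in this assay. Its nearest neighbour is compound 2, whose value lies within the usual scatter of that of compound 3, so the two cannot be ordered. Compound 1 lies far below both, beyond the scatter; compound 1 and compound 3 differ in two places, so their gap cannot be assigned to one change.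

Compound 4, `CC(C)C[C@H](N)c1cc(C(F)(F)F)ccc1N1CCN(C(=O)CCc2ccc(S(C)(=O)=O)cc2)CC1`, differs from compound 3 in one place: 4-(methylsulfonyl)phenyl in place of 2-chlorophenyl on a saturated chain carbon, two bonds along the chain from a carbonyl carbon. Within the data shown here, no measured step covers this replacement. Among the measured compounds shown here, the only step in hand, a 44-fold higher number from compound 1 to compound 2 (1.64 log units; beyond the scatter), concerns an added methoxy on the same aromatic ring and shows that a change on that ring can move the number a great deal. The change to compound 4 is larger in kind, exchanging a chlorine for a methylsulfonyl group and moving the substituent on the ring, so its direction is open. Compound 4 is therefore expected to land near compound 3, with a wide range and a slight lean towards a higher number, giving an estimated 3000 nM with a range of 700 nM to 13000 nM; this expected step is a 1.8-fold higher number from compound 3 to compound 4 (0.25 log units; within the scatter).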

Compound 4, inhibition constant: 4900 nM
For compound 4 the middle estimate is 1.6-fold (0.21 log units) below the measured one, within the range that was stated.
By their numbers in this assay, from the lowest: compound 1; then compounds 3, 2 and 4 (each within the scatter of the next, the first and the last beyond it).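

In this assay, the step is a 2.9-fold higher number from compound 3 to compound 4 (0.46 log units; beyond the scatter), so at this place, on a saturated chain carbon two bonds along the chain from a carbonyl carbon, exchanging one substituted phenyl for another does change the number, though only modestly. The earlier step on this ring concerned an added methoxy on a ring that keeps its chlorine, whereas this one replaces 2-chlorophenyl with 4-(methylsulfonyl)phenyl, an entering group that carries hydrogen-bond acceptors where the leaving group has none. Nothing in hand explains why the number moves in this direction.

Among these compounds, the single step joins the loss of the chlorine, the arrival of the methylsulfonyl group and the different place of the substituent on the ring, so the share of each stays unknown, and a plain phenyl at this place would be needed to begin separating them. Also open, as far as these compounds go, is how an amine or a carboxylic acid on the ring would read in place of the methylsulfonyl group, and whether this exchange would give a similar step on the core of compound 1.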